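The compounds below may be only part of what the source reports. "The series", "measured", "known", "first", "only" and "open" are said of these compounds alone.

Measured compounds:
- compound 1 `NS(=O)(=O)c1ccc(N/C(S)=N\c2ccnc3cc(C(F)(F)F)ccc23)cc1`: 36600 nM
- compound 2 `N=C(N)NS(=O)(=O)c1ccc(N/C(S)=N\c2ccnc3cc(C(F)(F)F)ccc23)cc1`: 23900 nM
- compound 3 `COc1cc(NS(=O)(=O)c2ccc(N/C(S)=N\c3ccnc4cc(C(F)(F)F)ccc34)cc2)nc(OC)n1`: 64500 nM

These three compounds share one core and differ only in what sits on the sulfonamide nitrogen. In a functional assay on AS49-RAW cells (Homo sapiens) for antiproliferative activity, read by sulforhodamine B assay, with a stated time of 48 h (a lower number here means a stronger inhibitor, a higher number a weaker inhibitor), compound 1 gives 36600 nM, the second highest of the three numbers; it sits closest to compound 2, as shown by a 1.5-fold lower number from compound 1 to compound 2 (0.19 log units; within the scatter), and furthest from compound 3, as shown by a 1.8-fold higher number from compound 1 to compound 3 (0.25 log units; within the scatter). Among the compounds with values here, both of these steps stay within the usual scatter, so none of the three can be called stronger or weaker than the others on these numbers alone; only the step of a 2.7-fold higher number from compound 2 to compound 3 (0.43 log units; beyond the scatter) is modest and just beyond the scatter.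

Compound 4 `COc1ncnc(NS(=O)(=O)c2ccc(N/C(S)=N\c3ccnc4cc(C(F)(F)F)ccc34)cc2)c1OC` is not yet measured. It differs from compound 1 as follows: 5,6-dimethoxypyrimidin-4-yl in place of hydrogen on a sulfonamide nitrogen. The step that bears most directly on it is a 1.8-fold higher number from compound 1 to compound 3 (0.25 log units; within the scatter), where a closely related dimethoxypyrimidinyl group on the same nitrogen changed the number only within the scatter. A similar outcome is therefore expected: for compound 4 the step of a 1.4-fold higher number from compound 1 to compound 4 (0.14 log units; within the scatter) is estimated to stay within or only just beyond the scatter, if anything towards a higher number. The estimate for compound 4 is 50000 nM, with a range from 20000 nM to 120000 nM.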

Compound 4, half-maximal inhibitory concentration: 81800 nM
Compound 4: the middle estimate sits 1.6-fold (0.21 log units) below what was measured; low and high end bracket the measured number.
By their numbers in this assay, from the lowest: compounds 2, 1, 3 and 4 (each within the scatter of the next, the first and the last beyond it).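

Compound 4 shows that a dimethoxypyrimidinyl group on the sulfonamide nitrogen can weaken the compound measurably, with a 2.2-fold higher number from compound 1 to compound 4 (0.35 log units; beyond the scatter) and a 3.4-fold higher number from compound 2 to compound 4 (0.53 log units; beyond the scatter), whereas the 2,6-dimethoxypyrimidin-4-yl group of compound 3 stayed within the scatter of compound 1. The two dimethoxypyrimidinyl groups themselves cannot be told apart, as a 1.3-fold higher number from compound 3 to compound 4 (0.10 log units; within the scatter) shows, so the placement of the methoxy groups on this ring has no demonstrated effect on the number. Nothing available here accounts for these differences.

From the compounds shown here alone, it remains open whether the methoxy groups or the pyrimidine ring itself matter, which a pyrimidin-4-yl group without methoxy groups would help to separate. Within the data shown here, an acetyl group on the same nitrogen would show how a small group other than the one in compound 2 behaves.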